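Chain extension on a para-methoxy phenylpropylamide

The compounds below may be only part of what the source reports. "The series", "measured", "known", "first", "only" and "open" are said of these compounds alone.

Three amides built on a methoxyphenylpropyl scaffold have been measured in an assay for binding affinity to melatonin receptor (Gallus gallus); a lower number here means a stronger inhibitor, a higher number a weaker inhibitor. Compound 1 `COc1ccccc1CCCNC(C)=O` gives 1430 nM. Compound 2 `CCC(=O)NCCCc1ccccc1OC` carries methyl in place of hydrogen on a saturated chain carbon bound to a carbonyl carbon and gives 374 nM, so the step of a 3.8-fold lower number from compound 1 to compound 2 (0.58 log units; beyond the scatter). Compound 3 `CCC(=O)NCCCc1ccc(OC)cc1` has a different core; how the two cores differ is not broken down here. In this assay compound 3 gives 2900 nM, the highest of the three numbers, and both compound 1 and compound 2 lie beyond the scatter below it.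

Compound 4 `CCCC(=O)NCCCc1ccc(OC)cc1` is not yet measured. It differs from compound 3 by methyl in place of hydrogen on a saturated chain carbon, two bonds along the chain from a carbonyl carbon. For the measured compounds named here, this is the same kind of change as the one from compound 1 to compound 2, but the place is not the same: there the methyl entered on a saturated chain carbon bound to a carbonyl carbon, here it enters two bonds along the chain from a carbonyl carbon. The account therefore expects a smaller step, a 2.1-fold lower number from compound 3 to compound 4 (0.32 log units; beyond the scatter), resting on the earlier gain of a 3.8-fold lower number from compound 1 to compound 2 (0.58 log units; beyond the scatter) while allowing that the further-out position need not repeat it. Compound 4 is estimated at 1400 nM, between 500 nM and 4000 nM.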

Compound 4, inhibition constant: 860 nM
Estimate against measurement, compound 4: 1.6-fold (0.21 log units) above; low and high end bracket the measured number.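

In this assay, methyl in place of hydrogen on a saturated chain carbon, two bonds along the chain from a carbonyl carbon, gives a 3.4-fold lower number from compound 3 to compound 4 (0.53 log units; beyond the scatter). Set beside the earlier step, the lengthening of the amide chain lowers the number by a similar amount on both cores: the same change on two cores in this assay, a 3.8-fold lower number (0.58 log units; beyond the scatter) from compound 1 to compound 2 and a 3.4-fold lower number (0.53 log units; beyond the scatter) from compound 3 to compound 4, 1.1-fold (0.05 log units) apart, within the scatter of two such steps. For the compounds shown here, this shows that the gain carried from the core of compound 1 to the core of compound 3 in this one assay, but it rests on only two pairs, and since the methyl enters at a different place in each, the effect of the core cannot be separated from that of the place.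

The compounds shown leave open whether each core responds alike when the methyl enters at the same place. They also leave open whether the trend continues with a longer chain on the carbonyl, or holds when a cyclopropyl group takes the place of the end of the chain.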